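Adding a butyl group to the ester chain of compound 3

The source may hold more compounds than are shown below. What is called first, only, known or untested is meant among the compounds shown, and "the series" means these compounds.

Compound 1 `CCCCCC(=O)OCC(C)(C)CC1=C(O)C(=O)c2ccccc2C1=O`: 169000 nM
Compound 2 `CCCCCCCCCCC(=O)OCC(C)(C)CC1=C(O)C(=O)c2ccccc2C1=O`: > 233000 nM
Compound 3 `CCCCCCCCCCCC(=O)OCC(C)(C)CC1=C(O)C(=O)c2ccccc2C1=O`: 249000 nM

These values come from an ADME assay on Vero cells (Chlorocebus sabaeus) for cytotoxicity, read by reporter gene assay, with a stated time of 4 days; a lower number here means a stronger inhibitor, a higher number a weaker inhibitor. For compound 2, > 233000 nM is a limit of the assay and not a number. That leaves two true numbers, and compound 3 stands level with the only other one. The measured step between them is a 1.5-fold higher number from compound 1 to compound 3 (0.17 log units; within the scatter).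

Compound 4 `CCCCCCCCCCCCCCCC(=O)OCC(C)(C)CC1=C(O)C(=O)c2ccccc2C1=O` extends the same chain further: butyl in place of hydrogen on a saturated chain carbon, ten or more bonds along the chain from a carbonyl carbon.

Two earlier steps also lengthen this chain and bear on the question. One is the step just given, and the other is an at least 1.3-fold higher number from compound 1 to compound 2 (0.13 log units; that floor lies within the scatter). A third, a step that the limit leaves unreadable from compound 2 to compound 3, adds no information on size. Neither readable step goes beyond the scatter, so no step beyond the scatter is expected here either. The expected change is a 1.0-fold higher number from compound 3 to compound 4 (0.00 log units; within the scatter). The estimate for compound 4 is 250000 nM, with an expected range from 130000 nM to 450000 nM.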

Compound 4, half-maximal inhibitory concentration: 4410 nM
The estimate for compound 4 lay 57-fold (1.75 log units) above the measured number, and the stated range ends above it.
By their numbers in this assay, from the lowest: compound 4; then compounds 1 and 3 (each within the scatter of the next).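

Adding the butyl group changes the outcome in this assay: the result is a 56-fold lower number from compound 3 to compound 4 (1.75 log units; beyond the scatter), whereas compound 1 and compound 3 stand within the scatter of each other despite their different chain lengths. The longest chain also separates clearly from the other two compounds, with a 38-fold lower number from compound 1 to compound 4 (1.58 log units; beyond the scatter) and an at least 52-fold lower number from compound 2 to compound 4 (1.72 log units; beyond the scatter), so at this place chain length does matter, but only once the chain reaches that of compound 4. Compound 2 carries a limit of the assay and not a number: the limit of > 233000 nM in this assay, at which 1 of the 4 values shown sits.

The compounds shown leave open where between the chains of compound 3 and compound 4 the change sets in, and whether a longer chain would lower the number further. They also leave open whether an amine or a carboxylic acid on this chain would keep the lower number.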